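A few compounds are considered here, and "the series" means these few. Any claim that something is new, unique, unknown or untested is made for them only; others in the source may bear on it.

Three compounds share one core: a branched acid bearing a chlorophenyl group, joined through an amide to a small aromatic ring. Compound 1 `CC(C)C(C(=O)Nc1ncccn1)c1ccc(Cl)cc1` carries a six-membered ring at that end; in a functional assay on CHO cells for agonist activity at Free fatty acid receptor 2 (Homo sapiens), read by cAMP accumulation (a lower number here means a smaller maximal response, a higher number a larger maximal response), compound 1 reaches 50%. Compound 2 `CC(C)C(C(=O)Nc1nc(-c2cccnc2)cs1)c1ccc(Cl)cc1` carries a five-membered ring bearing a pyridyl group, and in this assay compound 2 gives only a limit of the assay, < 30%. Such a limit is not a number: the limit of < 30% in this assay, at which 1 of the 3 values shown sits. Compound 3 `CC(C)[C@H](C(=O)Nc1ncc(C(F)(F)F)s1)c1ccc(Cl)cc1` carries the same five-membered ring with a trifluoromethyl group; in this assay compound 3 gives 95%, the higher of the two numbers, standing above compound 1 by more than the usual scatter.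

Compound 4 `CC(C)[C@H](C(=O)Nc1ncc(C(N)=O)s1)c1ccc(Cl)cc1` differs from compound 3 in one place: carbamoyl in place of trifluoromethyl on an aromatic carbon. Going by the values given here, no measured pair shows this exchange, so its effect is uncertain. A downward step beyond the scatter is expected in this assay, though not a fall to the limit. Compound 4 is thus estimated at about 55%, within 25% to 90%, an expected step of a number 40 percentage points lower from compound 3 to compound 4 (beyond the scatter).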

Compound 4, largest response reached (reported as efficacy), in percent of the reference or control that the assay uses: 59%
Compound 4: middle estimate off by 4 percentage points, on the low side; measured number inside the range.
By their numbers in this assay, from the lowest: compounds 1 and 4 (each within the scatter of the next); then compound 3. At a limit, below all of these: compound 2.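

The position next to the ring sulfur now has its first direct reading: in this assay, carbamoyl in place of trifluoromethyl gives a number 36 percentage points lower from compound 3 to compound 4 (beyond the scatter) and is the first step shown between two compounds that differ in one place. The maximal response therefore changes with the group at this position, yet the exchange does not take it down to a limit of the assay, since compound 4 still gives a measured number. Nothing measured here accounts for the size of this step.

On these data alone, two groups at one position make no trend, so how an amine, a carboxylic acid or a nitrile would behave there remains open. Also open, as far as these compounds go, is whether the same exchange would give a similar step on the six-membered ring of compound 1.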